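The source may report more compounds than this note shows. Statements on the series, on what has been measured and on what is new or still open speak of the compounds shown alone.

Among the measured compounds shown here, compound 2 `CCCSc1nc(N/N=C/c2ccc(N(C)C)cc2)c2nnn(Cc3ccccc3)c2n1` stands lowest of the two numbers so far: in a functional assay on MCF7 cells (Homo sapiens) for antiproliferative activity, read by MTT assay, with a stated time of 72 h (a higher number here means a weaker inhibitor, a lower number a stronger inhibitor), compound 2 gives 12200 nM, while compound 1 `CCCSc1nc(N/N=C/c2cccnc2)c2nnn(Cc3ccccc3)c2n1` gives 58700 nM. For the measured compounds named here, the one measured step, a 4.8-fold lower number from compound 1 to compound 2 (0.68 log units; beyond the scatter), swaps the ring attached to the carbon with a double bond to nitrogen. Compound 3 `CCCSc1nc(N/N=C/c2ccc([N+](=O)[O-])cc2)c2nnn(Cc3ccccc3)c2n1` keeps that phenyl ring and changes only its substituent: nitro in place of dimethylamino on an aromatic carbon. Going by the values given here, no measured step touches a nitro group, so the direction is open; a modest move either way would fit the spread seen. The estimated step is a 2.5-fold higher number from compound 2 to compound 3 (0.39 log units; beyond the scatter). Compound 3 is expected at 30000 nM, range 8000 nM to 100000 nM.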

Compound 3, half-maximal inhibitory concentration: 11000 nM
Estimate against measurement, compound 3: 2.7-fold (0.44 log units) above; low and high end bracket the measured number.
By their numbers in this assay, from the lowest: compounds 3 and 2 (each within the scatter of the next); then compound 1.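

Changing the substituent on the phenyl ring from dimethylamino to nitro leaves the number unmoved in this assay, with a 1.1-fold lower number from compound 2 to compound 3 (0.04 log units; within the scatter). The difference from the pyridin-3-yl of compound 1 therefore holds for both substituted phenyl rings, with a 5.3-fold lower number from compound 1 to compound 3 (0.73 log units; beyond the scatter). No evidence is available that bears on why these two substituents read alike.

Open, going by these compounds, is whether a plain phenyl ring, or one carrying a chlorine atom or a carboxylic acid at this place, would read the same. Also open, on these data alone, is whether any substituent here can move the number beyond the scatter.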